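Cyclohexyl to Benzyl on the Ring Nitrogen

This account rests on a few compounds, and the source may have more. Where it says the series, first, only, none or still open, it means among the compounds named here.

Measured in a functional assay on NCI/ADR-RES cells (Homo sapiens) for inhibition, read by sulforhodamine B assay, with a stated time of 48 h, tested at 10 uM; on this read-out higher numbers stand for more inhibition at the one concentration tested (going by the name of the read-out) and lower numbers for less inhibition:
Compound 1 `O=Cc1ccc(-c2cn3ccnc3c(-c3ccc4ncn(C5CCCCC5)c4c3)n2)cc1`: 37.4%
Compound 2 `Fc1ccc(-c2cn3ccnc3c(-c3ccc4ncn(C5CCCCC5)c4c3)n2)cc1`: 0.69%
Compound 3 `c1cn2cc(-c3ccc4c(c3)ncn4C3CCCCC3)nc(-c3ccc4ncn(C5CCCCC5)c4c3)c2n1`: 27%

Among these three numbers compound 3 stands second highest. Compound 1 gives a higher number, beyond the scatter, and compound 2 gives a lower one, also beyond the scatter. Among the compounds with values here, the one step measured within this set, a number 36.7 percentage points lower from compound 1 to compound 2 (beyond the scatter), is large, but it changes a group on an aromatic carbon of a different part of the molecule.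

Compound 4 `c1ccc(Cn2cnc3ccc(-c4nc(-c5ccc6c(c5)ncn6C5CCCCC5)cn5ccnc45)cc32)cc1` differs from compound 3 in one place: benzyl in place of cyclohexyl on an aromatic nitrogen. Within the data shown here, no measured step touches this ring nitrogen or exchanges a saturated ring for an aromatic one, so the only step recorded does not bear on this change. Without a comparable step, the plain expectation is a number near that of compound 3, with no step beyond the scatter in either direction, though the range must stay wide. Compound 4 is therefore estimated to give about 27%, between 8% and 46%. The expected step is no change at the digits printed from compound 3 to compound 4 (within the scatter), within the scatter.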

Compound 4, a percentage reported as inhibition, at one concentration (the size of the read-out at that concentration, not a potency): 99.5%
Compound 4: the middle estimate sits 72.5 percentage points below what was measured; measured number outside the range, above it.
By their numbers in this assay, from the lowest: compound 2; then compound 3; then compound 1; then compound 4.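

In this assay, the group on this aromatic nitrogen proves to have a strong influence: benzyl in place of cyclohexyl gives a number 72.5 percentage points higher from compound 3 to compound 4 (beyond the scatter). Within the data shown here, compounds 1, 2 and 3 all carry cyclohexyl on the corresponding nitrogen, and the only earlier step changes a group on an aromatic carbon, so they gave no sign of how much this site could move the read-out. Benzyl differs from cyclohexyl both in having an aromatic ring and in its heavy-atom count, and nothing measured here shows which of these differences matters or explains the rise.

The compounds shown do not separate these two differences: cyclohexylmethyl would keep the saturated ring with a connecting carbon, while phenyl would keep the aromatic ring without one, and a longer chain such as phenylethyl would test the length of the link. Also open, as far as these compounds go, is whether replacing the remaining cyclohexyl of compound 4 with benzyl would change the number further, and how potent compound 4 is, since a reading at one concentration is not a measure of potency.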